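The compounds below may be only part of what the source reports. "The series", "measured", "known", "first", "only" and "open" are said of these compounds alone.

Compound 3 `COc1cc2c(Oc3ccc(NC(=O)c4nn(-c5ccc(Cl)cc5)c(=O)cc4C)cc3F)ccnc2cc1OCCCN1CCCCC1` gives 460 nM in a functional assay on NCI-H460 cells (Homo sapiens) for inhibition, read by MTT assay, with a stated time of 72 h; on this read-out lower numbers stand for stronger inhibition and higher numbers for weaker inhibition. Compound 2 `COc1cc2c(Oc3ccc(NC(=O)c4nn(-c5ccc(Cl)cc5)c(=O)cc4C)cc3F)ccnc2cc1OCCCN1CCCC1` gives 360 nM, and compound 1 `COc1cc2c(Oc3ccc(NC(=O)c4nn(-c5cccc(F)c5)c(=O)cc4C)cc3F)ccnc2cc1OCCCN1CCC(C)CC1` gives 250 nM; all three numbers lie within the usual scatter of one another. Compound 4 `COc1cc2c(Oc3ccc(NC(=O)c4nn(-c5ccc(Cl)cc5)c(=O)cc4C)cc3F)ccnc2cc1OCCCN1CCC(C)CC1` differs from compound 3 by methyl in place of hydrogen on a saturated ring carbon. Going by the values given here, the only measured change at the amine end of the chain, a 1.3-fold higher number from compound 2 to compound 3 (0.11 log units; within the scatter), swapped one saturated ring for another and stayed within the scatter. Compound 1 carries the same 4-methylpiperidin-1-yl group but also differs elsewhere in its structure, so its value only shows that this group sits alongside a number close to the others. Compound 4 is therefore expected to show no step beyond the scatter, a 1.2-fold lower number from compound 3 to compound 4 (0.06 log units; within the scatter), with an estimate of 400 nM ranging from 200 nM to 800 nM.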

Compound 4, half-maximal inhibitory concentration: 370 nM
Estimate against measurement, compound 4: 1.1-fold (0.03 log units) above, within the range that was stated.
By their numbers in this assay, from the lowest: compounds 1, 2, 4 and 3 (each within the scatter of the next).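

In this assay, methyl on the saturated ring carbon three ring bonds from the ring nitrogen gives a 1.2-fold lower number from compound 3 to compound 4 (0.09 log units; within the scatter), so this position accepts the added carbon with no step beyond the scatter. Replacing pyrrolidin-1-yl with 4-methylpiperidin-1-yl gives a 1.0-fold higher number from compound 2 to compound 4 (0.01 log units; within the scatter), and 4-chlorophenyl in place of 3-fluorophenyl on the aromatic nitrogen gives a 1.5-fold higher number from compound 1 to compound 4 (0.17 log units; within the scatter), both also within the scatter. Nothing measured here explains these small steps. Still open, as far as these compounds go, is whether phenyl on this ring carbon, or morpholin-4-yl at the chain end, would move the number beyond the scatter.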